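The source may hold more compounds than are shown below. What is called first, only, known or untested is meant among the compounds shown, and "the series" means these compounds.

In a functional assay on HCT-116 cells (Homo sapiens) for cytotoxicity, with a stated time of 72 h (on this read-out higher numbers stand for weaker inhibition and lower numbers for stronger inhibition), compound 3 `COc1ccc(/C=C(/c2ccc(OC)cc2)c2cc(OC)c(OC)c(OC)c2Br)cc1` gives > 10000 nM, which is a limit of the assay and not a number. Compound 1 `COc1ccc(/C(=C/c2ccc(OC)c(O)c2)c2cc(OC)c(OC)c(OC)c2)cc1` gives > 10000 nM, also a limit. Among the compounds with values here, compound 2 `COc1ccc(/C=C(/c2ccc(OC)c(O)c2)c2cc(OC)c(OC)c(OC)c2)cc1O` gives 5000 nM, the only true number so far. The series is therefore marked by the limit of > 10000 nM in this assay, at which 2 of the 3 values shown sit.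

Compound 4 `COc1ccc(/C(=C/c2ccc(OC)c(O[Si](C)(C)C(C)(C)C)c2)c2cc(OC)c(OC)c(OC)c2Br)cc1` differs from compound 3 by a group of 8 heavy atoms (6 carbon, 1 oxygen, 1 silicon; no ring) in place of a hydrogen atom, on an aromatic carbon. The change lies on an aromatic carbon of a six-membered aromatic ring of carbon only, ortho to a methoxy group and meta to a large group.

Within the data shown here, only one measured step bears on this, and only loosely. Hydroxy in place of hydrogen on an aromatic carbon gives an at least 2.0-fold lower number from compound 1 to compound 2 (0.30 log units; that floor lies within the scatter). That step introduces a hydroxy rather than the group entering compound 4, and it starts from a limit, so it supports no firm prediction of a gain. Among the measured compounds shown here, with no measured step for this group, no change beyond the scatter is expected in this assay, and the most likely result is another limit. The expected step is a step that the limit leaves unreadable from compound 3 to compound 4.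

For compound 4 the estimated value is 12000 nM, with an expected range from 4000 nM to 30000 nM.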

Compound 4, half-maximal inhibitory concentration: > 10000 nM
Compound 4 was reported as a limit (the forecaster's own chance of this, stated with the estimate: 85%); the middle value lies beyond the limit too.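

Within the data shown here, compound 3 and compound 4 are both reported as limits of the assay, so the step between them cannot be read and no new step follows. Still open is whether the group entering compound 4 changes cytotoxicity in either direction, since the compounds shown give no true value for either side of this pair.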